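The source may report more compounds than this note shows. Statements on the series, on what has been measured and on what is new or still open speak of the compounds shown alone.

Of the compounds shown here, two have been measured so far in a functional assay on CCRF-CEM cells (Homo sapiens) for inhibition, read by sulforhodamine B assay, with a stated time of 48 h, tested at 10 uM; a higher number here means more inhibition at the concentration tested (going by the name of the read-out), a lower number less inhibition. Compound 1, `CC(=O)c1ccc(-c2cn3ccnc3c(-c3ccc4ncn(C5CCCCC5)c4c3)n2)cc1`, gives 1.1% in this assay. For the measured compounds named here, compound 2, `CCc1ccc(-c2cn3ccnc3c(-c3ccc4ncn(Cc5ccccc5)c4c3)n2)cc1`, gives 49.7% in this assay, and so stands highest of the two numbers known, with compound 1 the only neighbour, a long way below it and beyond the usual scatter of the measurement.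

Compound 3, `c1ccc(Cn2cnc3ccc(-c4nc(-c5cccc6ccccc56)cn5ccnc45)cc32)cc1`, is yet to be measured. It is reached from compound 2 by a single change: naphthalen-1-yl in place of 4-ethylphenyl on an aromatic carbon. Going by the values given here, nothing among the measured pair tells how such a swap of one aromatic group for another plays out in this assay, so there is no measured step to lean on. Among the compounds with values here, with only one number for the parent and no guide for the change itself, a modest fall from compound 2 seems the more likely outcome, although a result that stays within the scatter of compound 2 cannot be ruled out, and the step expected from compound 2 to compound 3 is a number 11.7 percentage points lower from compound 2 to compound 3 (beyond the scatter). For compound 3 the expected value in this assay is 38%, estimated to fall between 10% and 68%.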

Compound 3, a percentage reported as inhibition, at one concentration (the size of the read-out at that concentration, not a potency): 6.22%
Beside the measured number, compound 3's estimate is 31.8 percentage points above it; the whole stated range lies above it.
By their numbers in this assay, from the lowest: compounds 1 and 3 (each within the scatter of the next); then compound 2.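

In this assay, the group on this aromatic carbon of the six-membered aromatic ring with 2 nitrogen proves to matter on its own: naphthalen-1-yl in place of 4-ethylphenyl brings a large change, a number 43.5 percentage points lower from compound 2 to compound 3 (beyond the scatter), with everything else in compound 2 left as it was. For the compounds shown here, the earlier pair could not show this, since compound 1 and compound 2 differ in more than one place, whereas this is the first step that isolates a single change, and it shows that this swap of one carbon-only aromatic group for another, with no hydrogen-bond donors or acceptors on either side, is not a neutral one here. Nothing available explains why the number falls.

The compounds shown leave open how a plain phenyl, a naphthalen-2-yl or a 4-aminophenyl group would read at this carbon, and so whether the step goes with the second ring, with its point of attachment or with the loss of the ethyl chain. They also leave open whether the same swap would give a step of similar size with a cyclohexyl group in place of the benzyl group on the ring nitrogen of compound 3.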